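A few compounds are considered here, and "the series" means these few. Any claim that something is new, unique, unknown or untested is made for them only; others in the source may bear on it.

Compound 3 `O=C(Nc1ccc(Oc2ccnc3[nH]ccc23)cc1)c1cn(-c2ccc(Br)cc2)c2ccccc2c1=O` gives 220 nM in a functional assay on HepG2 cells (Homo sapiens) for inhibition, read by MTT assay, with a stated time of 72 h (a lower number here means a stronger inhibitor, a higher number a weaker inhibitor), the lowest of the three numbers: compound 2 `O=C(Nc1ccc(Oc2ccnc3[nH]ccc23)cc1)c1cn(-c2ccc(F)cc2)c2ccccc2c1=O` gives 450 nM and compound 1 `O=C(Nc1ccc(Oc2ccnc3[nH]ccc23)cc1)c1cn(-c2ccccc2)c2ccccc2c1=O` gives 2250 nM. Compound 4 `COc1ccc(-n2cc(C(=O)Nc3ccc(Oc4ccnc5[nH]ccc45)cc3)c(=O)c3ccccc32)cc1` differs from compound 3 by methoxy in place of bromo on an aromatic carbon. Among the compounds with values here, no measured step puts a methoxy at this carbon; the steps that bear on the site are a 10-fold lower number from compound 1 to compound 3 (1.01 log units; beyond the scatter), a 5.0-fold lower number from compound 1 to compound 2 (0.70 log units; beyond the scatter) and a 2.0-fold lower number from compound 2 to compound 3 (0.31 log units; beyond the scatter), so a substituent here has so far lowered the number, with bromo the best of the three. Methoxy is untested, so a modest loss against compound 3 is expected; the expected step is a 2.0-fold higher number from compound 3 to compound 4 (0.31 log units; beyond the scatter). Compound 4 is therefore estimated at 450 nM, with a range from 150 nM to 1500 nM.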

Compound 4, half-maximal inhibitory concentration: 5950 nM
Compound 4: the middle estimate sits 13-fold (1.12 log units) below what was measured; the whole stated range lies below it.
By their numbers in this assay, from the lowest: compound 3; then compound 2; then compound 1; then compound 4.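

Methoxy shows that a substituent on this carbon does not always lower the number: set against hydrogen it raises it (a 2.6-fold higher number from compound 1 to compound 4 (0.42 log units; beyond the scatter)), which runs against fluoro and bromo. Replacing either halogen with methoxy is a much larger step, both from fluoro (a 13-fold higher number from compound 2 to compound 4 (1.12 log units; beyond the scatter)) and from bromo (a 27-fold higher number from compound 3 to compound 4 (1.43 log units; beyond the scatter)). No evidence is available to explain this reversal.

The compounds shown leave open how a methyl, a chloro, a hydroxy or an amine at this carbon would stand, and so whether the rise belongs to methoxy alone.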